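The source may report more compounds than this note shows. Statements on the series, on what has been measured and on what is new or still open speak of the compounds shown alone.

Working notes on the series. The shared core of compound 1, `COc1ccc(Cn2cc(CSC(=S)N3CCNCC3)nn2)cc1`, carries a methoxy group on the aryl ring; in a functional assay on MGC-803 cells (Homo sapiens) for inhibition, read by MTT assay, with a stated time of 72 h (a lower number here means a stronger inhibitor, a higher number a weaker inhibitor), compound 1 is recorded as "not determined" (no result reported), so no single number stands for it. For the measured compounds named here, the only number in the set belongs to compound 2, `COc1ccc(Cn2cc(CSC(=S)N3CCN(C(=O)OC(C)(C)C)CC3)nn2)cc1`, which adds a tert-butoxycarbonyl group on the piperazine nitrogen; in this assay compound 2 gives 22800 nM, a weak result. Going by the values given here, no step between measured compounds can be drawn, since compound 1 and compound 2 differ elsewhere than in the aryl substituent and compound 1 has no value.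

Compound 3, `Fc1ccc(Cn2cc(CSC(=S)N3CCNCC3)nn2)cc1`, is reached from compound 1 by the change (fluoro in place of methoxy on an aromatic carbon). In this assay the expected step from this change is small, not beyond the usual scatter, in no settled direction, as nothing measured here speaks to the aryl substituent. With compound 2 at 22800 nM as the only anchor, compound 3 is expected to land near 20000 nM, in a range from 5000 nM to 80000 nM.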

Compound 3, half-maximal inhibitory concentration: 32500 nM
The estimate for compound 3 lay 1.6-fold (0.21 log units) below the measured number; the measured number falls inside the stated range.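

No new step can be read: in this assay compound 1 stands as "not determined" (no result reported), so the change to compound 3 has no size, and compound 2 differs from compound 3 in more than one place. On these data alone, what the aryl substituent contributes to activity on the shared core stays open. No evidence here bears on the result.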